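From fluoro to trifluoromethyl on compound 3

The source may hold more compounds than are shown below. What is called first, only, known or untested is meant among the compounds shown, and "the series" means these compounds.

Measured so far in an ADME assay on THP-1 cells (Homo sapiens) for cytotoxicity, read by flow cytometry and propidium iodide staining, with a stated time of 72 h; on this read-out lower numbers stand for stronger inhibition and higher numbers for weaker inhibition:
- compound 1 `Nc1ccc2oc(-c3cccc(C(F)(F)F)c3)c(O)c(=O)c2c1` gives 2000 nM
- compound 2 `COc1c(-c2cccc(C(F)(F)F)c2)oc2ccc(NC(C)=O)cc2c1=O` gives 52000 nM
- compound 3 `COc1c(-c2cccc(F)c2)oc2ccc(N)cc2c1=O` gives 34000 nM

Compound 3, at 34000 nM, lies within the scatter of compound 2, at 52000 nM. Compound 1, at 2000 nM, has a lower number than compound 3, and that gap lies beyond the scatter.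

The next compound is compound 4 `COc1c(-c2cccc(C(F)(F)F)c2)oc2ccc(N)cc2c1=O`. It has trifluoromethyl in place of fluoro on an aromatic carbon of a six-membered aromatic ring of carbon only, meta to a large group (trifluoromethyl in place of fluoro on an aromatic carbon).

Within the data shown here, no pair of measured compounds shows this change on its own, so the data offer no direct precedent for it. Compound 1 and compound 2 both carry trifluoromethyl, yet their values lie far apart, so the group alone does not settle the number. The expectation therefore starts from compound 3 at 34000 nM, and no step beyond the scatter is expected in this assay. The estimated step, leaning slightly towards a lower number, is a 1.3-fold lower number from compound 3 to compound 4 (0.12 log units; within the scatter). For compound 4 the estimated value is 26000 nM, with an expected range of 8000 nM to 70000 nM.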

Compound 4, half-maximal inhibitory concentration: 33000 nM
The estimate for compound 4 lay 1.3-fold (0.10 log units) below the measured number; measured number inside the range.
By their numbers in this assay, from the lowest: compound 1; then compounds 4, 3 and 2 (each within the scatter of the next).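

In this assay, trifluoromethyl in place of fluoro on an aromatic carbon, meta to a large group, gives a 1.0-fold lower number from compound 3 to compound 4 (0.01 log units; within the scatter), so at this position going from one heavy atom to four leaves the number within the scatter. Among these compounds, the same measurement supplies the first steps that can be read around the trifluoromethyl series: hydrogen in place of acetyl on the nitrogen gives a 1.6-fold lower number from compound 2 to compound 4 (0.20 log units; within the scatter), also within the scatter, whereas methyl in place of hydrogen on the oxygen gives a 17-fold higher number from compound 1 to compound 4 (1.22 log units; beyond the scatter), beyond it. Among the compounds shown here, of the three single changes now readable, only the one on the oxygen separates two compounds by more than the scatter, which fits the earlier observation that trifluoromethyl alone did not settle the number.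

No other data bear on why the change on the aromatic carbon makes so little difference or why the change on the oxygen makes so much. From the compounds shown here alone, it remains open whether a nitrile or a methoxy on that aromatic carbon would also stay within the scatter, and whether an ethyl in place of the methyl on the oxygen would keep the number of compound 4.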